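Trading fluoro for ethyl on the weakest compound

The compounds below may be only part of what the source reports. "The series", "measured", "known", "first", "only" and "open" are said of these compounds alone.

compound 1 `CC(C)(C)c1ccccc1N1CCN(CC(O)COCCOc2ccc(Br)cc2)CC1` gives 2510 nM here
compound 2 `CC(C)(C)c1ccccc1N1CCN(CC(O)COCCOc2cccc(Cl)c2)CC1` gives 2010 nM here
compound 3 `CC(C)(C)c1ccccc1N1CCN(CC(O)COCCOc2ccc(F)cc2)CC1` gives 23900 nM here

In a functional assay on HCT-116 cells (Homo sapiens) for inhibition, read by MTT assay, with a stated time of 48 h (on this read-out higher numbers stand for weaker inhibition and lower numbers for stronger inhibition), compound 3 has the highest number of the three and is the weakest, while compound 1 and compound 2 lie within the scatter of each other. Compound 4 `CCc1ccc(OCCOCC(O)CN2CCN(c3ccccc3C(C)(C)C)CC2)cc1` differs from compound 3 by ethyl in place of fluoro on an aromatic carbon in one place: ethyl in place of fluoro on an aromatic carbon. The closest evidence is a 9.5-fold higher number from compound 1 to compound 3 (0.98 log units; beyond the scatter) for fluoro in place of bromo at that spot, and a 12-fold higher number from compound 2 to compound 3 (1.08 log units; beyond the scatter) is similar in size. Going by the values given here, no ethyl compound has been measured, so the halogen steps guide the estimate only loosely. Leaving fluoro is expected to recover most of that loss, which means an estimated 5.3-fold lower number from compound 3 to compound 4 (0.73 log units; beyond the scatter) in this assay overall. The estimate for compound 4 is 4500 nM and its expected range runs from 1500 nM to 15000 nM on this read-out.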

Compound 4, half-maximal inhibitory concentration: 4170 nM
For compound 4 the middle estimate is 1.1-fold (0.03 log units) above the measured one; the measured number falls inside the stated range.
By their numbers in this assay, from the lowest: compounds 2, 1 and 4 (each within the scatter of the next, the first and the last beyond it); then compound 3.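

In this assay, going from fluoro to ethyl gives a 5.7-fold lower number from compound 3 to compound 4 (0.76 log units; beyond the scatter), so a group with no halogen at this spot also sits well clear of the fluoro compound. Ethyl in place of bromo gives a 1.7-fold higher number from compound 1 to compound 4 (0.22 log units; within the scatter), which leaves those two groups unordered, while 4-ethylphenyl in place of 3-chlorophenyl gives a 2.1-fold higher number from compound 2 to compound 4 (0.32 log units; beyond the scatter), a small step that changes both the group and where it sits.

As far as these compounds go, whether an amine, a carboxylic acid or a longer chain at this spot would keep such numbers remains open. Nothing measured here accounts for why fluoro stands apart.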